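The source may hold more compounds than are shown below. What is called first, only, known or untested is meant among the compounds shown, and "the series" means these compounds.

Measured so far:
compound 1 `O=C(Nc1ccc(Oc2ccnc3[nH]ccc23)cc1)c1nn(-c2ccccc2)ccc1=O`: 15600 nM in a functional assay on MCF7 cells (Homo sapiens) for cytotoxicity, read by MTT assay, with a stated time of 72 h; on this read-out higher numbers stand for weaker inhibition and lower numbers for stronger inhibition
compound 2 `O=C(Nc1ccc(Oc2ccnc3[nH]ccc23)cc1)c1nn(-c2ccc(Br)cc2F)ccc1=O`: 17900 nM
compound 3 `Cn1ccc2c(Oc3ccc(NC(=O)c4nn(-c5ccccc5)ccc4=O)cc3)ccnc21`: 45200 nM

Compound 4 `Cn1ccc2c(Oc3ccc(NC(=O)c4nn(-c5ccc(Br)cc5F)ccc4=O)cc3)ccnc21` has not been measured. It differs from compound 3 by 4-bromo-2-fluorophenyl in place of phenyl on an aromatic nitrogen. The same change, (4-bromo-2-fluorophenyl in place of phenyl on an aromatic nitrogen), was made from compound 1 to compound 2 and gave a 1.1-fold higher number from compound 1 to compound 2 (0.06 log units; within the scatter). The two cores differ by methyl in place of hydrogen on an aromatic nitrogen, which gave a 2.9-fold higher number from compound 1 to compound 3 (0.46 log units; beyond the scatter). The surroundings of the changed place are the same in both pairs, so the change is taken as the same change. Going by the values given here, the step from compound 3 to compound 4 is expected to be a 1.1-fold higher number from compound 3 to compound 4 (0.04 log units; within the scatter), resting on the single earlier instance a 1.1-fold higher number from compound 1 to compound 2 (0.06 log units; within the scatter) and on the value of compound 3, 45200 nM. Compound 4 is therefore estimated at 50000 nM in this assay, with a range from 20000 nM to 120000 nM.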

Compound 4, half-maximal inhibitory concentration: 19800 nM
Beside the measured number, compound 4's estimate is 2.5-fold (0.40 log units) above it; measured number outside the range, below it.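

In this assay, 4-bromo-2-fluorophenyl in place of phenyl on the aromatic nitrogen gives a 2.3-fold lower number from compound 3 to compound 4 (0.36 log units; beyond the scatter), and the gap to the earlier step on the other core stays within the scatter: the same change on two cores in this assay, a 1.1-fold higher number (0.06 log units; within the scatter) from compound 1 to compound 2 and a 2.3-fold lower number (0.36 log units; beyond the scatter) from compound 3 to compound 4, 2.6-fold (0.42 log units) apart, within the scatter of two such steps. Methyl in place of hydrogen on an aromatic nitrogen gives a 1.1-fold higher number from compound 2 to compound 4 (0.04 log units; within the scatter), and this step also agrees with its earlier counterpart within the scatter: the same change on two cores in this assay, a 2.9-fold higher number (0.46 log units; beyond the scatter) from compound 1 to compound 3 and a 1.1-fold higher number (0.04 log units; within the scatter) from compound 2 to compound 4, 2.6-fold (0.42 log units) apart, within the scatter of two such steps. Carrying either change from one core to the other is therefore not contradicted, but with only two instances of each change, this neither establishes that the steps transfer nor excludes a dependence on the core.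

Still open, as far as these compounds go, is whether benzyl on the same nitrogen would follow the same steps. From the compounds shown here alone, it is equally open whether a longer chain or an amine-bearing chain in place of the methyl would do so.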